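Moving the hydroxy group from compound 2 to compound 3

The source may report more compounds than this note shows. Statements on the series, on what has been measured and on what is new or still open speak of the compounds shown alone.

- compound 1 `O=C(Cc1csc2nc(-c3ccc(Br)cc3)cn12)N/N=C/c1ccccc1` gives < 100000 nM as a limit
- compound 2 `O=C(Cc1csc2nc(-c3ccc(Br)cc3)cn12)N/N=C/c1ccccc1O` gives 12000 nM as a number

For the measured compounds named here, in a functional assay on SK-MEL-28 cells (Homo sapiens) for inhibition, read by sulforhodamine B assay, with a stated time of 48 h (a lower number here means a stronger inhibitor of growth, a higher number a weaker inhibitor of growth), compound 2 gives 12000 nM as the only true number so far. For compound 1 the entry is a limit, (the limit of < 100000 nM in this assay, at which 1 of the 2 values shown sits), and not a number. Going by the values given here, the single measured step is a step that the limit leaves unreadable from compound 1 to compound 2 and so offers no size to carry forward.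

Compound 3 `O=C(Cc1csc2nc(-c3ccc(Br)cc3)cn12)N/N=C/c1ccc(O)cc1` is still to be measured. The change is 4-hydroxyphenyl in place of 2-hydroxyphenyl on a carbon with a double bond to nitrogen with 4-hydroxyphenyl in place of 2-hydroxyphenyl on a carbon with a double bond to nitrogen. Among the compounds with values here, the only anchor is compound 2 at 12000 nM and a value close to it is expected. The estimated step is a 1.3-fold higher number from compound 2 to compound 3 (0.10 log units; within the scatter) with no direction readable from the data. For compound 3 the expected value is 15000 nM within an estimated range of 4000 nM to 60000 nM for now.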

Compound 3, concentration for 50% growth inhibition: 60300 nM
Compound 3: middle estimate off by 4.0-fold (0.60 log units), on the low side; the whole stated range lies below it.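

In this assay, 4-hydroxyphenyl in place of 2-hydroxyphenyl on a carbon with a double bond to nitrogen is not a neutral change, giving a 5.0-fold higher number from compound 2 to compound 3 (0.70 log units; beyond the scatter). The two groups have the same atoms and the same donor and acceptor counts, so among these compounds the hydroxy group's location on the ring matters, not only its presence. The entry for compound 1 is a limit and not a number, so the steps from compound 1 cannot be read: the limit of < 100000 nM in this assay, at which 1 of the 3 values shown sits.

From the compounds shown here alone, whether 2-methoxyphenyl or 2-aminophenyl in place of 2-hydroxyphenyl would hold the number of compound 2 stays open. So does whether any group at this place can give a much lower number.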